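A second fluorine on the benzyl group

The compounds below may be only part of what the source reports. "The series", "measured", "known", "first", "only" and "open" are said of these compounds alone.

In a functional assay on A-375 cells (Homo sapiens) for activation, with a stated time of 3 days (a higher number here means that more compound is needed for the effect, a lower number that less compound is needed), compound 3 `O=C(Nc1ccc(-c2cscn2)cc1)C1CCCN(Cc2ccc(F)cc2)C1` gives 5000 nM, the higher of the two exact numbers, while compound 1 `O=C(Nc1ccc(-c2cscn2)cc1)C1CCCN(Cc2ccc(F)c(F)c2)C1` gives 1240 nM. Compound 2 `O=C(Nc1ccc(-c2cscn2)cc1)C1CCCN(C(=O)c2ccc(F)c(F)c2)C1` reads > 20000 nM, which is a limit of the assay. Compound 4 `O=C(Nc1ccc(-c2cscn2)cc1)C1CCCN(Cc2cccc(F)c2F)C1` carries 2,3-difluorophenyl in place of 4-fluorophenyl on a saturated chain carbon bound to an amine nitrogen in a ring. Swapping hydrogen for a fluoro gave a 4.0-fold higher number from compound 1 to compound 3 (0.61 log units; beyond the scatter), a modest step and the closest guide, although compound 1 holds 3,4-difluorobenzyl rather than 2,3-difluorobenzyl. The carbonyl change, an at least 16-fold higher number from compound 1 to compound 2 (1.20 log units; beyond the scatter), does not apply here. Compound 4 has no such carbonyl. A modest move to a lower number is therefore expected, a 2.3-fold lower number from compound 3 to compound 4 (0.36 log units; beyond the scatter). The estimate for compound 4 is 2200 nM, with an expected range of 700 nM to 7000 nM.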

Compound 4, half-maximal effective concentration: 10000 nM
Estimate against measurement, compound 4: 4.5-fold (0.66 log units) below; measured number above the stated range.
By their numbers in this assay, from the lowest: compound 1; then compounds 3 and 4 (each within the scatter of the next). At a limit, above all of these: compound 2.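

A second fluorine does not help wherever it sits: the 2,3-difluorobenzyl group of compound 4 loses what the 3,4-difluorobenzyl group gives, with an 8.1-fold higher number from compound 1 to compound 4 (0.91 log units; beyond the scatter). Against the single fluorine, a 2.0-fold higher number from compound 3 to compound 4 (0.30 log units; within the scatter), so the added fluorine brings no clear change in this arrangement. The reading of compound 2 is a limit, so an at least 2.0-fold lower number from compound 2 to compound 4 (0.30 log units; that floor lies within the scatter) gives only a floor.

Still open, from the compounds shown here alone, is whether the lower number of compound 1 needs both of its fluorines, or whether 3-fluorobenzyl or 3,4-dichlorobenzyl would give the same.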